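Quinolin-2-yl for Pyridin-2-yl on a Guanidine-Bearing Amidine

This account rests on a few compounds, and the source may have more. Where it says the series, first, only, none or still open, it means among the compounds named here.

compound 1, `CN(C(=O)C[C@@H](N)CCCCN)C1CN=C(Nc2ccc3ccccc3n2)NC1=O`: 50 nM
compound 2, `CN(C(=O)C[C@@H](N)CCCN=C(N)N)C1CN=C(Nc2ccccn2)NC1=O`: 70 nM

In a functional assay for inhibition, with Oryctolagus cuniculus as the target (a higher number here means a weaker inhibitor, a lower number a stronger inhibitor), compound 1 gives 50 nM and compound 2 gives 70 nM. Of the two numbers, compound 2 holds the highest, yet its gap to compound 1 lies within the scatter, so the two compounds cannot be told apart on these data. Compound 3 `CN(C(=O)C[C@@H](N)CCCN=C(N)N)C1CN=C(Nc2ccc3ccccc3n2)NC1=O` has not yet been measured. It differs from compound 2 in one place: quinolin-2-yl in place of pyridin-2-yl on an amine nitrogen. Compound 1 already carries the quinolin-2-yl group, though on a different chain, and because its 50 nM in this assay sits close to that of compound 2, the exchange is not expected to move the number beyond the scatter. Compound 3 is therefore expected to give about 45 nM in this assay, within 15 nM to 130 nM. The expected step is a 1.6-fold lower number from compound 2 to compound 3 (0.19 log units; within the scatter), a small move toward a lower number, itself inside the scatter.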

Compound 3, half-maximal inhibitory concentration: 100 nM
The estimate for compound 3 lay 2.2-fold (0.35 log units) below the measured number; the measured number falls inside the stated range.
By their numbers in this assay, from the lowest: compounds 1, 2 and 3 (each within the scatter of the next).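

In this assay, quinolin-2-yl in place of pyridin-2-yl on an amine nitrogen gives a 1.4-fold higher number from compound 2 to compound 3 (0.15 log units; within the scatter), so adding a six-membered aromatic ring of carbon only at this position does not shift the number beyond the scatter. With quinolin-2-yl kept in place, exchanging the group of 2 heavy atoms at the chain end for the group of 4 heavy atoms gives a 2.0-fold higher number from compound 1 to compound 3 (0.30 log units; within the scatter), so this single exchange cannot be told apart from the scatter either. The data offer no measurement that could explain either result.

Going by these compounds, it remains open whether a phenyl or a pyrimidin-2-yl group on this amine nitrogen would separate from pyridin-2-yl and quinolin-2-yl. On these data alone, it is also open whether a longer chain ending in the guanidine would move the number beyond the scatter.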